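Trifluoromethoxy in place of trifluoromethyl on the aryl ring

The source may hold more compounds than are shown below. What is called first, only, known or untested is meant among the compounds shown, and "the series" means these compounds.

Measured so far in an assay on HEK293 cells for displacement of a labelled ligand from 5-hydroxytryptamine receptor 7 (Rattus norvegicus), read by radioligand binding; a lower number here means a stronger inhibitor, a higher number a weaker inhibitor:
compound 1, `Cc1ccc(-c2c3c(nn2C(C)C)CCNCC3)cc1`, gives 6 nM
compound 2, `CC(C)n1nc2c(c1-c1ccc(C(F)(F)F)cc1)CCNCC2`, gives 15 nM

Within the data shown here, compound 2 stands at the higher of the two numbers, and the only step leading to it, a 2.5-fold higher number from compound 1 to compound 2 (0.40 log units; beyond the scatter), is a modest weakening. Compound 3, `CC(C)n1nc2c(c1-c1ccc(OC(F)(F)F)cc1)CCNCC2`, differs from compound 2 in one place: trifluoromethoxy in place of trifluoromethyl on an aromatic carbon. Among the measured compounds shown here, the single measured step that bears on this change is the one at the same aromatic carbon, a 2.5-fold higher number from compound 1 to compound 2 (0.40 log units; beyond the scatter); it shows that exchanging the group at this position shifts the number only modestly. For the measured compounds named here, no measured compound carries a trifluoromethoxy group, so the direction rests on that one step alone. The expected outcome is a small move toward a somewhat higher number, a 1.5-fold higher number from compound 2 to compound 3 (0.17 log units; within the scatter), not far beyond the scatter. Compound 3 is estimated at 22 nM, with a likely range from 7 nM to 70 nM.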

Compound 3, inhibition constant: 5000 nM
Beside the measured number, compound 3's estimate is 230-fold (2.36 log units) below it, and the stated range ends below it.
By their numbers in this assay, from the lowest: compound 1; then compound 2; then compound 3.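

In this assay, trifluoromethoxy on this aromatic carbon brings a 330-fold higher number from compound 2 to compound 3 (2.52 log units; beyond the scatter) and, measured against the methyl group, an 830-fold higher number from compound 1 to compound 3 (2.92 log units; beyond the scatter). The earlier pair had suggested a tolerant position, with only a 2.5-fold higher number from compound 1 to compound 2 (0.40 log units; beyond the scatter), yet the change to compound 3 shows that one extra oxygen atom in the group can take a compound from strong to weak binding. Nothing in the data given explains this sharp drop.

The compounds shown leave open whether the loss follows from the oxygen atom itself or from the trifluoromethoxy group as a whole. A methoxy group, an ethoxy chain or a single chlorine atom on the same carbon would help separate these possibilities, and would show how narrow the range of accepted groups is.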